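Swapping a benzodioxin for 3-ethylphenyl on the shared core

A few compounds are considered here, and "the series" means these few. Any claim that something is new, unique, unknown or untested is made for them only; others in the source may bear on it.

Values in a physicochemical assay for solubility, read by spectrophotometry, in phosphate buffer, with a stated time of 18 h, at pH 7.4; on this read-out lower numbers stand for lower solubility and higher numbers for higher solubility:
- Compound 1 `CCCc1ccc(-c2nc3c(c(C)nn3-c3ccccc3)c(-c3ccccc3O)c2C#N)cc1`: 6500 nM
- Compound 2 `Cc1nn(-c2ccccc2)c2nc(-c3ccc4ccccc4c3)c(C#N)c(-c3ccccc3O)c12`: 1800 nM
- Compound 3 `Cc1nn(-c2ccccc2)c2nc(-c3ccc4c(c3)OCCO4)c(C#N)c(-c3ccccc3O)c12`: 11000 nM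

Compound 3 stands level with its nearest neighbour, with a 1.7-fold higher number from compound 1 to compound 3 (0.23 log units; within the scatter), and clear of the lowest number, with a 6.1-fold higher number from compound 2 to compound 3 (0.79 log units; beyond the scatter). Compound 4 `CCc1cccc(-c2nc3c(c(C)nn3-c3ccccc3)c(-c3ccccc3O)c2C#N)c1` carries 3-ethylphenyl in place of 2,3-dihydro-1,4-benzodioxin-6-yl on an aromatic carbon. The closest measured guide is the exchange of 4-propylphenyl for that same benzodioxin group, a 1.7-fold higher number from compound 1 to compound 3 (0.23 log units; within the scatter). The naphthalen-2-yl steps, a 3.6-fold lower number from compound 1 to compound 2 (0.56 log units; beyond the scatter) and a 6.1-fold higher number from compound 2 to compound 3 (0.79 log units; beyond the scatter), involve a group less like the incoming one. A small downward move in this assay, not beyond the scatter, is therefore expected: a 1.8-fold lower number from compound 3 to compound 4 (0.26 log units; within the scatter). Compound 4 is estimated at 6000 nM, with an expected range of 2500 nM to 14000 nM.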

Compound 4, solubility: 11000 nM
Compound 4: the middle estimate sits 1.8-fold (0.26 log units) below what was measured; low and high end bracket the measured number.
By their numbers in this assay, from the lowest: compound 2; then compounds 1, 3 and 4 (each within the scatter of the next).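

At this carbon, ortho to a cyano group, this assay shows no change at the digits printed from compound 3 to compound 4 (within the scatter), so 3-ethylphenyl, with 0 hydrogen-bond acceptors, reads level with 2,3-dihydro-1,4-benzodioxin-6-yl, with 2. Among these four groups only naphthalen-2-yl stands apart: a 6.1-fold higher number from compound 2 to compound 4 (0.79 log units; beyond the scatter) contrasts with a 1.7-fold higher number from compound 1 to compound 4 (0.23 log units; within the scatter), which leaves 3-ethylphenyl and 4-propylphenyl level. Nothing given here explains these numbers.

On these data alone, whether an amine or a carboxylic acid on the phenyl group at this position would leave the number level stays open.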